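This account rests on a few compounds, and the source may have more. Where it says the series, first, only, none or still open, it means among the compounds named here.

Working notes on the series. Compound 3 `Nc1cc(N)c2nc(-c3ccccc3)c(Sc3ccc(Cl)c(Cl)c3)nc2c1` gives 13800 nM in a functional assay on SF-268 cells (Homo sapiens) for inhibition, read by sulforhodamine B assay, with a stated time of 48 h (on this read-out higher numbers stand for weaker inhibition of growth and lower numbers for stronger inhibition of growth), the highest of the two numbers shown. Compound 1 `Nc1cc(N)c2nc(-c3ccccc3)c(NCc3ccc(F)cc3)nc2c1` gives 2820 nM in this assay, and the step of a 4.9-fold higher number from compound 1 to compound 3 (0.69 log units; beyond the scatter) is the only one whose size can be read. Compound 2 `COc1ccc(Sc2nc3cc(N)cc(N)c3nc2-c2ccccc2)cc1` gives < 100000 nM in this assay, which is a limit of the assay and not a number. The steps a step that the limit leaves unreadable from compound 1 to compound 2 and a step that the limit leaves unreadable from compound 2 to compound 3 thus show nothing of their size. Compound 4 `Nc1cc(N)c2nc(-c3ccccc3)c(Oc3ccc(F)cc3)nc2c1` is not yet measured; it carries 4-fluorophenoxy in place of (3,4-dichlorophenyl)sulfanyl on an aromatic carbon. Among the compounds with values here, only the step from compound 1 to compound 3 bears on this change, and only in part. For compound 4 a step of a 2.0-fold lower number from compound 3 to compound 4 (0.29 log units; within the scatter) toward stronger inhibition is expected. Compound 4 is thus estimated at 7000 nM, within 2000 nM to 30000 nM.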

Compound 4, concentration for 50% growth inhibition: 13800 nM
Beside the measured number, compound 4's estimate is 2.0-fold (0.29 log units) below it; the measured number falls inside the stated range.
By their numbers in this assay, from the lowest: compound 1; then compounds 3 and 4 (each within the scatter of the next).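

At this position, next to the ring nitrogen, 4-fluorophenoxy in place of (3,4-dichlorophenyl)sulfanyl gives no change at the digits printed from compound 3 to compound 4 (within the scatter) in this assay, so a different linking atom and a different ring substitution together leave the read-out unmoved. The (4-fluorobenzyl)amino group now stands apart from two aryl-linked groups rather than one, with a 4.9-fold higher number from compound 1 to compound 4 (0.69 log units; beyond the scatter). The steps to and from compound 2 cannot be read, its value being a limit of the assay: the limit of < 100000 nM in this assay, at which 1 of the 4 values shown sits.

As far as these compounds go, the linking atom and the ring substitution change together in this pair, so their separate contributions stay open. Also open, from the compounds shown here alone, is how a group without an aromatic ring, such as morpholine or a simple alkyl amine, would read at this position.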